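Swapping a methylfuran for a thiophene on the core

A few compounds are considered here, and "the series" means these few. Any claim that something is new, unique, unknown or untested is made for them only; others in the source may bear on it.

Measured compounds:
- compound 1, `COc1cccc(CNc2nc(N)c3nc(-c4ccc(C)o4)sc3n2)c1`: 70 nM
- compound 2, `Cc1ccc(-c2nc3c(N)nc(NCc4cccs4)nc3s2)o1`: 71 nM
- compound 3, `Nc1nc(NCc2cccnc2)nc2sc(-c3ccco3)nc12`: 7.12 nM

In an assay on CHO cells for displacement of a labelled ligand from adenosine receptor A1 (Homo sapiens), read by scintillation counting, with a stated time of 90 min (a lower number here means a stronger inhibitor, a higher number a weaker inhibitor), compound 1 gives 70 nM, the second highest of the three numbers. Its nearest neighbour is compound 2, whose value of 71 nM sits within the scatter of compound 1; the step of a 1.0-fold higher number from compound 1 to compound 2 (0.01 log units; within the scatter) changes only the group on the saturated chain carbon bound to the ring nitrogen. Compound 3 stands furthest away with 7.12 nM, but it differs from compound 1 in two places at once, so its lower number cannot be tied to a single change.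

Compound 4, `COc1cccc(CNc2nc(N)c3nc(-c4cccs4)sc3n2)c1`, keeps the same chain as compound 1 and changes the group on the core: thiophen-2-yl in place of 5-methylfuran-2-yl on an aromatic carbon. Among the compounds with values here, none of the measured steps touches this position, so there is no direct precedent for this change. Within the data shown here, the only single step seen, from compound 1 to compound 2, lay within the scatter, and it concerned a different place.

Compound 4 is therefore expected to land close to compound 1, with an estimated step of a 1.1-fold lower number from compound 1 to compound 4 (0.03 log units; within the scatter), an estimate of 65 nM and a range from 20 nM to 200 nM in this assay.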

Compound 4, inhibition constant: 37 nM
Compound 4: middle estimate off by 1.8-fold (0.24 log units), on the high side, within the range that was stated.
By their numbers in this assay, from the lowest: compound 3; then compounds 4, 1 and 2 (each within the scatter of the next).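

In this assay, within the data shown here, the exchange on the core gives a 1.9-fold lower number from compound 1 to compound 4 (0.28 log units; within the scatter), the first reading at this position. It shows that this aromatic carbon, on the ring with 1 nitrogen and 1 sulfur, can carry thiophen-2-yl in place of 5-methylfuran-2-yl with no difference beyond the scatter, so these two five-membered aromatic rings cannot be told apart in this assay. No measurement is available that would explain how either group acts at this position.

On these data alone, both groups compared here are five-membered aromatic rings, so it remains open whether a very different group at the same carbon, such as an amine or a carboxylic acid, would also leave the number within the scatter. As far as these compounds go, it is equally open whether this exchange would give a similar step with the thiophen-2-yl chain of compound 2.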